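Quinoline tetrazoles: carboxy replacement at the same ring position

The source may report more compounds than this note shows. Statements on the series, on what has been measured and on what is new or still open speak of the compounds shown alone.

Measured so far in a functional assay on the whole organism (strain Sprague-Dawley) for inhibition, with Rattus norvegicus as the target; on this read-out lower numbers stand for an effect already at smaller amounts and higher numbers for an effect only at larger amounts of compound:
- compound 1 `COc1ccc2cc(-c3nn[nH]n3)cnc2c1`: 5 mg/kg
- compound 2 `COc1cccc2cc(-c3nn[nH]n3)cnc12`: 2.5 mg/kg
- compound 3 `c1nc2ccc(C3CCCCC3)cc2cc1-c1nn[nH]n1`: 5 mg/kg

Compound 1 stands level with compound 3 at the digits given, the two together the highest numbers of the three. Compound 2 gives a lower number, but that gap lies within the scatter, so no order among the three can be read from these values. Among the measured compounds shown here, no pair differs in one place only, so no step between measured compounds is available.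

Compound 4 `COc1ccc2cc(C(=O)O)cnc2c1` differs from compound 1 in one place: carboxy in place of 2H-tetrazol-5-yl on an aromatic carbon. Nothing in the measured set shows how this assay responds to a change at this place, so the expectation rests on the structural change alone. For compound 4 a modestly higher number than for compound 1 is estimated, giving 10 mg/kg with a range from 3 mg/kg to 30 mg/kg. The expected step of a 2.0-fold higher number from compound 1 to compound 4 (0.30 log units; within the scatter) is thus a moderate weakening, possibly beyond the scatter; a result within the scatter of compound 1 would not be surprising.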

Compound 4, minimum effective dose: > 25 mg/kg
Compound 4: a limit, no number (the forecaster's own chance of this, stated with the estimate: 15%); at least 2.5-fold (0.39 log units) between middle value and limit.
By their numbers in this assay, from the lowest: compounds 2, 1 and 3 (each within the scatter of the next). At a limit, above all of these: compound 4.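

At the aromatic carbon two atoms from the ring nitrogen, this assay now gives a first readable step: carboxy in place of 2H-tetrazol-5-yl gives an at least 5.0-fold higher number from compound 1 to compound 4 (0.69 log units; beyond the scatter). The earlier compounds shown here all carry 2H-tetrazol-5-yl and none differs from another in one place only, so they could not show that this position responds to a change of group beyond the scatter. The result for compound 4 is a limit and not a number, so the step has a lower bound but no upper one: the limit of > 25 mg/kg in this assay, at which 1 of the 4 values shown sits.

Going by these compounds, whether carboxy in place of 2H-tetrazol-5-yl has a like effect on the cores of compound 2 and compound 3 remains open. Also open, on these data alone, is how a primary amide or a sulfonamide at this position would read in this assay.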